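Trimming the Sulfonyl Side Chain: Expected Microsomal Stability

This account rests on a few compounds, and the source may have more. Where it says the series, first, only, none or still open, it means among the compounds named here.

Measured in an ADME assay on microsomes from liver (Rattus norvegicus) for metabolic stability, with a stated time of 10 min; on this read-out higher numbers stand for a more stable compound and lower numbers for a less stable compound:
compound 1, `CC(C)OC(=O)NCCS(=O)(=O)NC(=O)c1ccc(Nc2nc(NC3(c4ccc(Cl)cc4)CC3)nc(OCC(F)(F)F)n2)cc1`, gives 73%
compound 2, `Cc1ccccc1S(=O)(=O)NC(=O)c1ccc(Nc2nc(NC3(c4ccc(Cl)cc4)CC3)nc(OCC(F)(F)F)n2)cc1`, gives 100%
compound 3, `CC(C)C(=O)NCCS(=O)(=O)NC(=O)c1ccc(Nc2nc(NC3(c4ccc(Cl)cc4)CC3)nc(OCC(F)(F)F)n2)cc1`, gives 84%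

Compound 1 stands lowest of the three in this assay; compound 3 is nearest to it and compound 2 furthest. Compound 4, `CS(=O)(=O)NC(=O)c1ccc(Nc2nc(NC3(c4ccc(Cl)cc4)CC3)nc(OCC(F)(F)F)n2)cc1`, is not yet measured and differs from compound 1 by hydrogen in place of ((isopropoxycarbonyl)amino)methyl on a saturated chain carbon bound to a sulfonyl sulfur. Both measured steps that start from compound 1 bear on this: a number 27 percentage points higher from compound 1 to compound 2 (beyond the scatter), and a number 11 percentage points higher from compound 1 to compound 3 (beyond the scatter). Each of those changes at the sulfonyl substituent moved the number upward, so a modest rise beyond the scatter is expected here as well, a number 15 percentage points higher from compound 1 to compound 4 (beyond the scatter). Compound 4 is therefore estimated at 88% in this assay, with a range from 76% to 100%.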

Compound 4, percent of the compound remaining: 85%
Estimate against measurement, compound 4: 3 percentage points above; the range from low to high includes it.
By their numbers in this assay, from the lowest: compound 1; then compounds 3 and 4 (each within the scatter of the next); then compound 2.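

Taking away the ((isopropoxycarbonyl)amino)methyl portion altogether still raises the number in this assay (a number 12 percentage points higher from compound 1 to compound 4 (beyond the scatter)), so the rise at this position needs no aromatic group on the sulfonyl sulfur. Removing ((isopropylcarbonyl)amino)methyl leaves the number in place (a number 1 percentage points higher from compound 3 to compound 4 (within the scatter)), so the isopropyl amide chain and methyl read alike here. Methyl nevertheless does not match 2-methylphenyl (a number 15 percentage points lower from compound 2 to compound 4 (beyond the scatter)).

From the compounds shown here alone, whether an amine, a carboxylic acid or a longer plain alkyl chain on the sulfonyl sulfur would stay level with compound 4 remains open. No supporting evidence accounts for these differences.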